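From Dichlorobenzyl to Fluorobenzyl in a Platelet Inhibitor Series

The compounds below may be only part of what the source reports. "The series", "measured", "known", "first", "only" and "open" are said of these compounds alone.

Of the compounds shown here, three have been measured in a functional assay (Platelet, plasma) for inhibition, with Homo sapiens as the target; a higher number here means a weaker inhibitor, a lower number a stronger inhibitor. Compound 1 `N#Cc1cc2c(nc1N1CCC(C(=O)NS(=O)(=O)Cc3ccccc3)CC1)CCC(F)C2=O` gives 255000 nM. Compound 2 `N#Cc1cc2c(nc1N1CCC(C(=O)NS(=O)(=O)Cc3cc(Cl)cc(Cl)c3)CC1)COC2=O` gives 30500 nM. Compound 3 `N#Cc1cc2c(nc1N1CCC(F)(C(=O)NS(=O)(=O)Cc3ccccc3)CC1)COC2=O` gives 1210 nM. Among these three numbers, compound 2 stands second highest: compound 1 is the nearest and lies higher by a margin beyond the scatter, while compound 3 is the furthest and lies lower, again beyond the scatter. Among the measured compounds shown here, no pair among the measured compounds differs in one place only, so no single measured step can be read off from them.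

Compound 4 `N#Cc1cc2c(nc1N1CCC(C(=O)NS(=O)(=O)Cc3ccc(F)cc3)CC1)COC2=O` has not been measured. It differs from compound 2 by a single change: 4-fluorophenyl in place of 3,5-dichlorophenyl on a saturated chain carbon bound to a sulfonyl sulfur. For the measured compounds named here, none of the measured compounds carries a 4-fluorophenyl group, and the other measured compounds differ from compound 2 in more than this one place, so the data give no direct guide to this exchange. The expectation is a small step in this assay toward a higher number, a 1.3-fold higher number from compound 2 to compound 4 (0.12 log units; within the scatter), of a size that may not exceed the scatter. Compound 4 is therefore expected to give about 40000 nM, with a plausible range from 10000 nM to 150000 nM.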

Compound 4, half-maximal inhibitory concentration: 3500 nM
For compound 4 the middle estimate is 11-fold (1.06 log units) above the measured one; the whole stated range lies above it.
By their numbers in this assay, from the lowest: compound 3; then compound 4; then compound 2; then compound 1.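

In this assay, the exchange of 3,5-dichlorophenyl for 4-fluorophenyl on a saturated chain carbon bound to a sulfonyl sulfur gives an 8.7-fold lower number from compound 2 to compound 4 (0.94 log units; beyond the scatter). Among the compounds shown here, this is the first step that isolates a single place, and it shows that the aryl group at this position alone can move the number beyond the scatter, here toward a stronger inhibitor. The exchange removes two chlorine atoms and adds one fluorine. The step is a single combined change that cannot be divided among the loss of chlorine, the gain of fluorine and the altered substitution pattern. Nothing available explains its size.

The compounds shown leave open how an unsubstituted phenyl or a 4-chlorophenyl group would stand at this position on the core shared by compound 2 and compound 4, comparisons that would help to separate the parts of this exchange. Going by these compounds, it also remains open whether a methoxy group on the ring, a pyridine ring in place of the phenyl ring or a longer chain to the sulfonyl sulfur would continue the same direction.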